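Working notes: from compound 1 to its 4-hydroxyphenyl analogue

This account rests on a few compounds, and the source may have more. Where it says the series, first, only, none or still open, it means among the compounds named here.

Compound 1 `COc1ccc(-c2noc(-c3ccncc3)n2)cc1OC1CCCC1`: 9330 nM
Compound 2 `COc1cc(-c2noc(-c3ccncc3)n2)ccc1OCc1ccccc1`: > 1000000 nM

In a functional assay on MIA PaCa-2 cells (Homo sapiens) for antiproliferative activity, read by MTT assay, with a stated time of 24 h (a higher number here means a weaker inhibitor, a lower number a stronger inhibitor), compound 1 gives 9330 nM, the only exact figure so far. Compound 2 is reported as > 1000000 nM, which is a limit of the assay and not a number. Going by the values given here, the two measured compounds differ in more than one place, so they provide no single-change step to draw on.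

The next compound to be measured is compound 3 `COc1ccc(-c2noc(-c3ccc(O)cc3)n2)cc1OC1CCCC1`. It has 4-hydroxyphenyl in place of pyridin-4-yl on an aromatic carbon of the five-membered aromatic ring with 2 nitrogen and 1 oxygen (4-hydroxyphenyl in place of pyridin-4-yl on an aromatic carbon). The remainder of compound 1 is retained.

Among the compounds with values here, with no measured precedent for this exchange, the expectation is anchored on compound 1 at 9330 nM and remains loose. A modest move towards weaker inhibition in this assay is expected, close to the usual scatter in size. The expected step is a 2.1-fold higher number from compound 1 to compound 3 (0.33 log units; beyond the scatter). For compound 3 the estimated value is 20000 nM, with an expected range of 3000 nM to 120000 nM.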

Compound 3, half-maximal inhibitory concentration: 480 nM
Beside the measured number, compound 3's estimate is 42-fold (1.62 log units) above it; measured number below the stated range.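

In this assay, the group on an aromatic carbon of the five-membered aromatic ring, next to the ring nitrogen and next to the ring oxygen, proves decisive for the read-out: placing 4-hydroxyphenyl there in place of pyridin-4-yl gives a 19-fold lower number from compound 1 to compound 3 (1.29 log units; beyond the scatter). Going by these compounds alone, this is the first single-change step, and it shows that this position is far from indifferent to the six-membered aromatic ring it carries, with the rest of compound 1 retained. By the counts, the change removes the ring nitrogen and adds one hydrogen-bond donor, while the hydrogen-bond acceptor count stays the same.

A single pair cannot show whether the step comes from gaining the hydroxyl or losing the ring nitrogen, and a plain phenyl, a 4-methoxyphenyl or a 4-aminophenyl at this position would separate the two. Compound 2 offers no further comparison, as it differs from the others in more than one place and its entry is a limit of the assay, not a number: the limit of > 1000000 nM in this assay, at which 1 of the 3 values shown sits.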